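The compounds below may be only part of what the source reports. "The series", "measured", "known", "first", "only" and "open" are said of these compounds alone.

Measured compounds:
Compound 1 `COc1ccc(N(CC(=O)NCCCSc2ccccc2)C(=O)CCSC2=C(C)C(=O)c3ccccc3C2=O)cc1`, 4.2
Compound 2 `COc1ccc(N(CC(=O)NCCC[Se]c2ccccc2)C(=O)c2ccccc2)cc1`, 3.1

In a physicochemical assay for lipophilicity, read by HPLC, measured as octanol-water partition (a higher number here means a more lipophilic compound, a lower number a more polar compound), compound 1 gives 4.2, the higher of the two numbers; compound 2 gives 3.1, a number beyond the scatter lower, but the two structures differ in more than one place, so the values alone stand. Compound 3 `COc1ccc(N(CC(=O)NCCC[Se]c2ccccc2)C(=O)CCSC2=C(C)C(=O)c3ccccc3C2=O)cc1` has not yet been measured. It differs from compound 1 by a group of 7 heavy atoms (6 carbon, 1 selenium; one six-membered aromatic ring of carbon only) in place of a group of 7 heavy atoms (6 carbon, 1 sulfur; one six-membered aromatic ring of carbon only), on a saturated chain carbon, three bonds along the chain from an amide-type nitrogen. Going by the values given here, no measured step shows this exchange; the step is expected to be small and upward, or none beyond the scatter. Compound 3 is therefore estimated at 4.4, in the range 4 to 4.8, an expected step of a number 0.20 log units higher from compound 1 to compound 3 (within the scatter).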

Compound 3, partition coefficient: 4.23
For compound 3 the middle estimate is 0.17 log units above the measured one; the range from low to high includes it.
By their numbers in this assay, from the lowest: compound 2; then compounds 1 and 3 (each within the scatter of the next).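

In this assay, putting the selenium group in place of phenylsulfanyl, on a saturated chain carbon, three bonds along the chain from an amide-type nitrogen, gives a number 0.03 log units higher from compound 1 to compound 3 (within the scatter), so this exchange leaves no readable change at this place. The earlier compounds shown here held no pair differing in this one place, and so could not show this. Nothing measured here offers an explanation for the result. The compounds shown leave open whether the same exchange would read alike in the core of compound 2. They also leave open how an amine, a carboxylic acid or a longer chain at this place would read.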